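A few compounds are considered here, and "the series" means these few. Any claim that something is new, unique, unknown or untested is made for them only; others in the source may bear on it.

Compound 1 `Nc1ccc(-c2nc3ccc(F)cc3s2)cc1I` gives < 10 nM
Compound 2 `Nc1ccc(-c2nc3ccc(F)cc3s2)cc1Cl` gives < 10 nM
Compound 3 `Cc1cc(-c2nc3cc(F)c(F)cc3s2)ccc1N` gives < 10 nM

All three were read in a functional assay on cells (Cancer cell lines, Homo sapiens) for inhibition; on this read-out higher numbers stand for weaker inhibition of growth and lower numbers for stronger inhibition of growth. Each entry is a limit and not a number: the limit of < 10 nM in this assay, at which 3 of the 3 values shown sit. Compound 3 therefore stands only at its limit of < 10 nM.

Compound 4 `Cc1cc(-c2nc3ccc(F)cc3s2)ccc1N` differs from compound 3 by hydrogen in place of fluoro on an aromatic carbon. Within the data shown here, the one measured step, a step that the two limits leave unreadable from compound 1 to compound 2, is a different change and gives no size to carry over. Like compound 4, compound 2 carries a single fluoro, and it sits at a limit, < 10 nM. No shift beyond the scatter is therefore expected, and the expected step is a step that the limit leaves unreadable from compound 3 to compound 4. For compound 4 the estimated value is 5 nM, with an expected range from 1 nM to 20 nM.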

Compound 4, concentration for 50% growth inhibition: < 10 nM
Compound 4 was reported as a limit (the forecaster's own chance of this, stated with the estimate: 70%); the middle value lies beyond the limit too.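

Among these compounds, no step to compound 4 from compound 1, compound 2 or compound 3 can be read, since all the values are limits: the limit of < 10 nM in this assay, at which 4 of the 4 values shown sit. On these data alone, how these four compounds rank, and how large any of these changes is, stays open.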